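Swapping the Ring Substituent on a Shared Core

A few compounds are considered here, and "the series" means these few. Any claim that something is new, unique, unknown or untested is made for them only; others in the source may bear on it.

Of the compounds shown here, two built on one shared core have been measured in a functional assay on CHO-K1 cells for antagonist activity at melanin-concentrating hormone receptor 1 (Homo sapiens), read by inositol phosphate accumulation; a higher number here means a weaker inhibitor, a lower number a stronger inhibitor. Compound 1 `Cc1nc(N2CCN(C3CCOCC3)CC2)nc2ccc(NC(=O)COc3ccc(OC(F)(F)F)cc3)cc12` gives 31 nM in this assay. Compound 2 `Cc1nc(N2CCN(C(=O)C3CCC3)CC2)nc2ccc(NC(=O)COc3ccc(OC(F)(F)F)cc3)cc12` gives 45 nM. The step of a 1.5-fold higher number from compound 1 to compound 2 (0.16 log units; within the scatter) shows that exchanging the group on that ring nitrogen hardly moved the number. Among the two numbers, that of compound 2 stands at one end, yet its gap to compound 1 is within the scatter, so neither compound can be called the weaker or the stronger inhibitor.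

Compound 3 `Cc1nc(N2CCC(O)(C3CC3)CC2)nc2ccc(NC(=O)COc3ccc(OC(F)(F)F)cc3)cc12` has not yet been measured. It differs from compound 2 by 4-cyclopropyl-4-hydroxypiperidin-1-yl in place of 4-(cyclobutylcarbonyl)piperazin-1-yl on an aromatic carbon. Within the data shown here, the only measured step touching this region is the small one between compound 1 and compound 2, so compound 3 is expected to give 40 nM in this assay, between 12 nM and 130 nM, with an expected step of a 1.1-fold lower number from compound 2 to compound 3 (0.05 log units; within the scatter) that stays within the scatter.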

Compound 3, half-maximal inhibitory concentration: 33 nM
Beside the measured number, compound 3's estimate is 1.2-fold (0.08 log units) above it; measured number inside the range.
By their numbers in this assay, from the lowest: compounds 1, 3 and 2 (each within the scatter of the next).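

In this assay, putting 4-cyclopropyl-4-hydroxypiperidin-1-yl in place of 4-(cyclobutylcarbonyl)piperazin-1-yl gives a 1.4-fold lower number from compound 2 to compound 3 (0.13 log units; within the scatter), and putting it in place of 4-(oxan-4-yl)piperazin-1-yl gives a 1.1-fold higher number from compound 1 to compound 3 (0.03 log units; within the scatter), so the three numbers cannot be told apart. Compounds 1 and 2 both carry a piperazine at this position, whereas compound 3 shows that a piperidine ring with one ring nitrogen, a hydrogen-bond donor and a cyclopropyl group can stand on this aromatic carbon with no step beyond the scatter. No measurement here accounts for this result.

From the compounds shown here alone, the hydroxyl and cyclopropyl groups arrive together in compound 3, so what each contributes on its own stays open. Also open, going by these compounds, is whether an open-chain amine such as dimethylamino, with no ring at all, would give a number in the same range.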